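Methyl in Place of Phenyl on a Saturated Ring Carbon

The source may report more compounds than this note shows. Statements on the series, on what has been measured and on what is new or still open speak of the compounds shown alone.

Of the three measured compounds, only compound 1 `C=C(Br)C(=O)Nc1ccc2oc(C(=O)NCCNC(=O)c3cc(OCC4(c5ccc(Cl)cc5)CC(=C)C(=O)O4)nn3C)cc2c1` gives a number: in a functional assay on K562 cells (Homo sapiens) for antiproliferative activity (a higher number here means a weaker inhibitor, a lower number a stronger inhibitor), compound 1 gives 710 nM. Compound 2 `C=C1CC(COc2cc(C(=O)O)n(C)n2)(c2ccc(-c3ccccc3)cc2)OC1=O` reaches only the limit of the assay, > 10000 nM. Compound 3 `C=C1CC(COc2cc(C(=O)O)n(C)n2)(c2ccccc2)OC1=O` likewise reaches only a limit; in this assay compound 3 gives > 10000 nM. Among the measured compounds shown here, the single measured step, a step that the two limits leave unreadable from compound 2 to compound 3, cannot be read in size or direction because of the limit of > 10000 nM in this assay, at which 2 of the 3 values shown sit, at which both of its compounds sit. Compound 3 therefore stands at the limit, with no readable step leading to it.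

Compound 4 `C=C1CC(C)(COc2cc(C(=O)O)n(C)n2)OC1=O` differs from compound 3 by methyl in place of phenyl on a saturated ring carbon. For the measured compounds named here, no measured step bears on this change, and the one step that exists is unreadable. Both compounds carrying the acid of compound 3 sit at the limit, so compound 4 is expected to sit there as well. The step that the limit leaves unreadable from compound 3 to compound 4 is estimated to be none beyond the scatter. Compound 4 is estimated at 15000 nM, within 7000 nM to 40000 nM.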

Compound 4, half-maximal inhibitory concentration: > 10000 nM
Compound 4 was reported as a limit; the forecaster's own chance of this, stated with the estimate: 85%; the middle value lies beyond the limit too.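

No new step can be read from compound 3 to compound 4, because both compounds sit at a limit rather than at a number: the limit of > 10000 nM in this assay, at which 3 of the 4 values shown sit. The compounds shown leave open how compound 2, compound 3 and compound 4 would rank in this assay.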